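Tribrominated phenol cyclopentenediones: removing the methoxycarbonyl

This account rests on a few compounds, and the source may have more. Where it says the series, first, only, none or still open, it means among the compounds named here.

compound 1 `COC(=O)C1=C(c2cc(Br)c(O)c(Br)c2)C(=O)C(c2cc(Br)c(O)c(Br)c2)(c2cc(Br)c(O)c(Br)c2)C1=O`: > 10000 nM
compound 2 `COC(=O)C1=C(c2cc(Br)c(O)c(Br)c2)[C@](OC)(c2cc(Br)c(O)c(Br)c2)O[C@@]1(C(=O)OC)c1cc(Br)c(O)c(Br)c1`: > 10000 nM

In a functional assay on K562 cells (Homo sapiens) for cytotoxicity, read by sulforhodamine B assay, with a stated time of 72 h (a lower number here means a stronger inhibitor, a higher number a weaker inhibitor), compound 1 gives only a limit of the assay, > 10000 nM. Compound 2 likewise gives only a limit, > 10000 nM. Both values sit at the limit of > 10000 nM in this assay, at which 2 of the 2 values shown sit, so compound 1 stands nowhere distinct on the numbers shown. Compound 3 `O=C1C=C(c2cc(Br)c(O)c(Br)c2)C(=O)C1(c1cc(Br)c(O)c(Br)c1)c1cc(Br)c(O)c(Br)c1` differs from compound 1 by hydrogen in place of methoxycarbonyl on a double-bonded ring carbon. Among the compounds with values here, no step between measured compounds is known here. The expected step that the limit leaves unreadable from compound 1 to compound 3 is small, with no direction beyond the scatter. Compound 3 is expected at 15000 nM, within 4000 nM to 60000 nM, and most likely reported again only as a limit.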

Compound 3, half-maximal inhibitory concentration: > 10000 nM
Compound 3: only a limit was reported (the forecaster's own chance of this, stated with the estimate: 70%); the middle value lies beyond the limit too.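

No step can be read between compound 1 and compound 3, since both are reported only as limits: the limit of > 10000 nM in this assay, at which 3 of the 3 values shown sit.

The compounds shown leave open how strong any of them actually is, and whether exchanging methoxycarbonyl for hydrogen changes the value at all.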